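A Nitrile Replaces Chlorine on the Sulfonyl Ring

The source may hold more compounds than are shown below. What is called first, only, known or untested is meant among the compounds shown, and "the series" means these compounds.

In a functional assay on HepG2 cells (Homo sapiens) for cytotoxicity, read by MTT assay, with a stated time of 24 h (a lower number here means a stronger inhibitor, a higher number a weaker inhibitor), compound 3 `O=C1/C(=C/c2ccccc2F)CN(S(=O)(=O)c2ccc(Cl)cc2)C/C1=C\c1ccccc1F` gives 10900 nM. Among the three compounds measured, compound 3 stands second highest. Compound 1 `O=C1/C(=C/c2ccccc2F)CN(S(=O)(=O)c2ccc(O[N+](=O)[O-])cc2)C/C1=C\c1ccccc1F` gives 16500 nM, which lies within the scatter of compound 3. Compound 2 `O=C1/C(=C/c2ccccc2F)CN(S(=O)(=O)c2ccc(C(F)(F)F)cc2)C/C1=C\c1ccccc1F` gives 4900 nM; the step was a 2.2-fold higher number from compound 2 to compound 3 (0.35 log units; beyond the scatter). Compound 4 `N#Cc1ccc(S(=O)(=O)N2C/C(=C\c3ccccc3F)C(=O)/C(=C/c3ccccc3F)C2)cc1` differs from compound 3 in one place: cyano in place of chloro on an aromatic carbon. The earlier swaps at the same position gave a 3.4-fold lower number from compound 1 to compound 2 (0.53 log units; beyond the scatter) and a 1.5-fold lower number from compound 1 to compound 3 (0.18 log units; within the scatter), so changes there have shifted the number only modestly. For compound 4 a step of a 1.3-fold lower number from compound 3 to compound 4 (0.11 log units; within the scatter) is therefore expected, a small lowering that may well fall within the scatter. The estimate for compound 4 is 8500 nM, with a range from 4000 nM to 18000 nM.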

Compound 4, half-maximal inhibitory concentration: 16500 nM
For compound 4 the middle estimate is 1.9-fold (0.29 log units) below the measured one, and the stated range covers the measured number.
By their numbers in this assay, from the lowest: compound 2; then compounds 3, 1 and 4 (each within the scatter of the next).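

In this assay the groups chloro, nitrooxy and cyano cannot be told apart on this aromatic carbon, with a 1.5-fold higher number from compound 3 to compound 4 (0.18 log units; within the scatter) and no change at the digits printed from compound 1 to compound 4 (within the scatter) as the steps. Trifluoromethyl alone stands apart, now also through a 3.4-fold higher number from compound 2 to compound 4 (0.53 log units; beyond the scatter) as a further step, so compound 2 is the only one of the four whose steps to all others lie beyond the scatter.

From the compounds shown here alone, whether an amine or a carboxylic acid on this carbon would join the group of three or match compound 2 remains open. Nothing shown here explains why trifluoromethyl differs from the other three groups.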